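The source may report more compounds than this note shows. Statements on the series, on what has been measured and on what is new or still open speak of the compounds shown alone.

Among the measured compounds shown here, in a functional assay on CHO cells for antagonist activity at corticotropin-releasing factor receptor 1 (Homo sapiens), read by cAMP accumulation (on this read-out lower numbers stand for stronger inhibition and higher numbers for weaker inhibition), compound 3 `Cc1nc(NC(C2CC2)C2CC2)c2nc(C)n(-c3ccc(C#N)cc3)c2n1` gives 62 nM, the second highest of the three numbers measured so far. Compound 1 `COc1ccc(-n2c(C)nc3c(NC(C4CC4)C4CC4)nc(C)nc32)c(C)c1` gives 14 nM and stands nearest to it, while compound 2 `COc1ccc(-n2c(C3CCCO3)nc3c(NC(C4CC4)C4CC4)nc(C)nc32)cc1` gives 867 nM and lies furthest away. For the measured compounds named here, the only measured step that alters the aryl group on the aromatic nitrogen is a 4.4-fold higher number from compound 1 to compound 3 (0.65 log units; beyond the scatter), a modest rise when 4-cyanophenyl replaces 4-methoxy-2-methylphenyl. Compound 4 `Cc1nc(NC(C2CC2)C2CC2)c2nc(C)n(-c3ccc(F)cc3)c2n1` differs from compound 3 by fluoro in place of cyano on an aromatic carbon. Going by the values given here, no measured pair isolates a fluoro against a cyano on this ring, so the expectation rests on the observation that changing the substituent pattern on this aryl group produced only a modest shift in a 4.4-fold higher number from compound 1 to compound 3 (0.65 log units; beyond the scatter). A step of similar or smaller size is therefore expected, with the number for compound 4 estimated a little lower than that of compound 3. The estimate for compound 4 in this assay is 45 nM, with a range from 15 nM to 140 nM. This estimate corresponds to an expected step of a 1.4-fold lower number from compound 3 to compound 4 (0.14 log units; within the scatter).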

Compound 4, inhibition constant: 91 nM
Beside the measured number, compound 4's estimate is 2.0-fold (0.31 log units) below it; low and high end bracket the measured number.
By their numbers in this assay, from the lowest: compound 1; then compounds 3 and 4 (each within the scatter of the next); then compound 2.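

Swapping cyano for fluoro on this aromatic carbon makes no difference that can be read in this assay, since a 1.5-fold higher number from compound 3 to compound 4 (0.17 log units; within the scatter) stays within the scatter, even though the two groups differ in heavy atoms and hydrogen-bond acceptors. With 4-fluorophenyl, as with 4-cyanophenyl, the number stands beyond the scatter from that of the 4-methoxy-2-methylphenyl compound: a 6.5-fold higher number from compound 1 to compound 4 (0.81 log units; beyond the scatter) is a modest step, as is a 4.4-fold higher number from compound 1 to compound 3 (0.65 log units; beyond the scatter). No measurement at hand explains either result.

The compounds shown leave open whether the methoxy or the methyl of 4-methoxy-2-methylphenyl goes with the lower number of compound 1, as each step changes both at once. They also leave open how an amine, a carboxylic acid or a longer alkyl chain on this aromatic carbon would read.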